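This account rests on a few compounds, and the source may have more. Where it says the series, first, only, none or still open, it means among the compounds named here.

Measured so far:
- compound 1, `COC(=O)c1cc(-c2cccc(NC(=O)c3ccc(/C=C/C(=O)c4ccccc4Br)cc3)c2)on1`: > 40 ug/mL
- compound 2, `O=C(O)c1ccc(/C=C/C(=O)c2ccc(Cl)cc2)cc1`: < 10 ug/mL
- compound 3, `COC(=O)c1cc(-c2cccc(NC(=O)c3ccc(/C=C/C(=O)c4ccccc4O)cc3)c2)on1`: "not determined" (no result reported)

In an ADME assay on Vero cells (Chlorocebus sabaeus) for cytotoxicity, read by MTT assay, with a stated time of 72 h (a lower number here means that less compound is tolerated, a higher number that more compound is tolerated), compound 1 gives > 40 ug/mL, and this is a limit of the assay rather than a number. Compound 2 gives < 10 ug/mL in this assay, which is likewise a limit. For compound 3 no result was reported in this assay. For the measured compounds named here, compound 1 therefore stands at the tolerated end of the values shown, sitting at the limit of > 40 ug/mL in this assay, at which 1 of the 3 values shown sits, while compound 2 sits at the limit of < 10 ug/mL in this assay, at which 1 of the 3 values shown sits; with only limits and one missing entry, no step between measured compounds can be sized.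

Compound 4, `COC(=O)c1cc(-c2cccc(NC(=O)c3ccc(/C=C/C(=O)c4cccc(OC)c4)cc3)c2)on1`, shares the core of compound 1 and differs from it in one place: 3-methoxyphenyl in place of 2-bromophenyl on a carbonyl carbon. Because compound 1 gives only > 40 ug/mL, a limit, in this assay, the starting point for compound 4 is itself open-ended. Without any measured step to lean on, the expected step from compound 1 to compound 4 in this assay is a number no higher from compound 1 to compound 4 (the limit leaves the size open), that is, no change beyond the usual scatter. Compound 4 is therefore expected to give about 40 ug/mL in this assay, within a range of 20 ug/mL to 80 ug/mL, and it is quite possible that this assay again reports only a limit for compound 4.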

Compound 4, half-maximal cytotoxic concentration: > 100 ug/mL
Compound 4: a limit, no number (the forecaster's own chance of this, stated with the estimate: 60%); at least 2.5-fold (0.39 log units) between middle value and limit.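

In this assay, compound 1 and compound 4 each give only a limit of the assay, not a number, and the step between them cannot be read. The compounds shown leave open whether 3-methoxyphenyl in place of 2-bromophenyl on a carbonyl carbon changes how much compound the cells tolerate, and by how much.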